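The source may report more compounds than this note shows. Statements on the series, on what has been measured and on what is new or still open speak of the compounds shown alone.

Values in a functional assay on the whole organism (strain Sprague-Dawley) for inhibition, with Rattus norvegicus as the target, with a stated time of 10 min; a higher number here means that more compound is needed for the effect, a lower number that less compound is needed:
compound 1 `O=C(O)c1cnc(-c2ccccc2)[nH]c1=O`: 50 mg/kg
compound 2 `O=C(O)c1cnc(-c2cccc(C(F)(F)F)c2)[nH]c1=O`: 33 mg/kg
compound 3 `COc1cccc(-c2ncc(C(=O)O)c(=O)[nH]2)c1`: 10 mg/kg

Compound 2 cannot be told apart from compound 1, as a 1.5-fold lower number from compound 1 to compound 2 (0.18 log units; within the scatter) shows, while compound 3 stands clear of it, with a 3.3-fold lower number from compound 2 to compound 3 (0.52 log units; beyond the scatter). Compound 4 `CCOC(=O)c1cnc(-c2cccc(C(F)(F)F)c2)[nH]c1=O` matches compound 2 except for one change: ethyl in place of hydrogen on an oxygen next to a carbonyl group. Among the compounds with values here, no measured step touches this place. All three measured steps exchange groups on an aromatic carbon, so they bear on the change only indirectly, giving a scale but no direction. On that scale, a 5.0-fold lower number from compound 1 to compound 3 (0.70 log units; beyond the scatter) shows what a single substitution has done in this assay. The data offer no direct guide to the new change, so only a small shift towards a higher number is expected, and the uncertainty is wide. The expected step is a 1.4-fold higher number from compound 2 to compound 4 (0.13 log units; within the scatter). For compound 4 the estimated value is 45 mg/kg, with an expected range of 14 mg/kg to 150 mg/kg.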

Compound 4, dose for 50% inhibition: 50 mg/kg
For compound 4 the middle estimate is 1.1-fold (0.05 log units) below the measured one, within the range that was stated.
By their numbers in this assay, from the lowest: compound 3; then compounds 2, 1 and 4 (each within the scatter of the next).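

Within the data shown here, the change from carboxy to ethoxycarbonyl is the first step at this place on an oxygen next to a carbonyl group, and in this assay it gives a 1.5-fold higher number from compound 2 to compound 4 (0.18 log units; within the scatter). On the core of compound 2, then, the hydrogen of the carboxy group can give way to ethyl with no change that can be told from scatter, so a free carboxy hydrogen is not needed for the effect in this pair. Nothing at hand explains why this exchange leaves the number within the scatter.

From the compounds shown here alone, whether the same holds on the methoxy-bearing core of compound 3 remains open, as this single pair concerns the trifluoromethyl series only. Going by these compounds, it is also open how a longer chain on this oxygen, or an amide in place of the carboxy group, would behave.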